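Anilino for fluorobenzyl at the chlorinated core

The source may hold more compounds than are shown below. What is called first, only, known or untested is meant among the compounds shown, and "the series" means these compounds.

Compound 3, `CN1CCN(c2ccc(Nc3ncc(Cl)c(NCc4ccc(F)cc4)n3)nc2)CC1`, gives 39700 nM in an ADME assay on L02 cells (Homo sapiens) for inhibition, read by CCK-8 assay, with a stated time of 48 h (a higher number here means a weaker inhibitor of growth, a lower number a stronger inhibitor of growth), the highest of the two numbers recorded in the series. Its nearest neighbour is compound 2, `Cc1ccccc1Nc1nc(Nc2ccccn2)ncc1Cl`, which gives 6150 nM in this assay. Compound 1, `Cc1ccccc1Nc1nc(Nc2ccccc2)ncc1Cl`, sits at a limit of this assay rather than at a number, > 100000 nM (the limit of > 100000 nM in this assay, at which 1 of the 3 values shown sits). Within the data shown here, the only step measured between compounds that differ in a single place is an at least 16-fold lower number from compound 1 to compound 2 (1.21 log units; beyond the scatter). That step concerns an exchange on a nitrogen on an aromatic ring and shows that a change of this kind can move the number a long way. Compound 4, `COc1cccc(Nc2nc(Nc3ccc(N4CCN(C)CC4)cn3)ncc2Cl)c1`, differs from compound 3 by 3-methoxyphenyl in place of 4-fluorobenzyl on a nitrogen on an aromatic ring. Among the measured compounds shown here, no measured step covers this particular exchange, so its direction cannot be read from the series; the step from compound 1 to compound 2 only indicates the size such changes may reach. A modest shift is expected, a 1.6-fold lower number from compound 3 to compound 4 (0.20 log units; within the scatter), with wide uncertainty around it. Compound 4 is estimated at 25000 nM, within a range from 8000 nM to 80000 nM.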

Compound 4, concentration for 50% growth inhibition: 3470 nM
Compound 4: the middle estimate sits 7.2-fold (0.86 log units) above what was measured; the whole stated range lies above it.
By their numbers in this assay, from the lowest: compounds 4 and 2 (each within the scatter of the next); then compound 3. At a limit, above all of these: compound 1.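

The exchange of 4-fluorobenzyl for 3-methoxyphenyl, both with one six-membered aromatic ring of carbon only, gives in this assay an 11-fold lower number from compound 3 to compound 4 (1.06 log units; beyond the scatter), so the group on this nitrogen can move the number a long way. Among these compounds, the only earlier step, an at least 16-fold lower number from compound 1 to compound 2 (1.21 log units; beyond the scatter), is a different exchange, pyridin-2-yl in place of phenyl, and says nothing directly about this one. No measurement at hand bears on a cause for the new step.

As far as these compounds go, the exchange alters the methylene-linked benzyl, the fluorine and the methoxy together, so the share of each in the step stays open. From the compounds shown here alone, how a plain benzyl, a fluorophenyl or a longer chain such as phenethyl on this nitrogen would read also stays open.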